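A Second Methoxy on an Inactive Compound

This account rests on a few compounds, and the source may have more. Where it says the series, first, only, none or still open, it means among the compounds named here.

Compound 3 (`COc1ccccc1C1CC(=O)c2c(O)c(C)c(O)c(C)c2O1`) has no number in a functional assay on VSMC cells (Rattus norvegicus) (a lower number here means a stronger inhibitor, a higher number a weaker inhibitor), and is recorded only as "not active" (no number reported). Within the data shown here, two relatives on the same core give the only readings nearby. Compound 1 (`Cc1c(O)c(C)c2c(c1O)C(=O)CC(c1ccccc1Cl)O2`) reads > 20000 nM, which is a limit of the assay and not a number. Compound 2 (`Cc1c(O)c(C)c2c(c1O)C(=O)CC(c1ccccc1[N+](=O)[O-])O2`) gives 9900 nM. Compound 4 (`COc1ccc(C2CC(=O)c3c(O)c(C)c(O)c(C)c3O2)c(OC)c1`) differs from compound 3 by one change, methoxy in place of hydrogen on an aromatic carbon. Among the measured compounds shown here, the only measured step, an at least 2.0-fold lower number from compound 1 to compound 2 (0.30 log units; that floor lies within the scatter), exchanges other groups, and its floor lies within the scatter, so it offers no measured size for adding a methoxy. No step beyond the scatter is therefore expected in this assay, and the starting point remains compound 3 at "not active" (no number reported). A reading near the limit, or again no number at all, seems likely. For compound 4 the expected value is 20000 nM, with an estimated range from 8000 nM to 50000 nM.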

Compound 4, half-maximal inhibitory concentration: "not active" (no number reported)
The entry for compound 4 holds no number, so the estimate cannot be set against anything.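

In this assay compound 3 gives "not active" (no number reported) and compound 4 gives "not active" (no number reported), so no step can be read between them. The compounds shown leave open whether the added methoxy changes inhibition at all, and by how much.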